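This account rests on a few compounds, and the source may have more. Where it says the series, first, only, none or still open, it means among the compounds named here.

All three measured compounds were tested in an assay on LX2 cells for inhibition of COL1A1 promoter (Homo sapiens), read by a luciferase reporter, with a stated time of 24 h, tested at 50 uM; a higher number here means a stronger effect of the compound at the concentration tested, a lower number a weaker effect:

compound 1, `Cc1cc(-n2cc(C(=O)Nc3cc(F)cc(F)c3)c(=O)c3ccc(N(C)C)nc32)ccc1OCCCCCCC[N+]1(C)CCCC1`, gives 35.9%;
compound 2, `CN(C)c1ccc2c(=O)c(C(=O)Nc3cc(F)cc(F)c3)cn(-c3ccc(OCCCCCCC[N+]4(C)CCCC4)c(Cl)c3)c2n1`, gives 2.59%;
compound 3, `Cc1ccc(-n2cc(C(=O)Nc3cc(F)cc(F)c3)c(=O)c3ccc(N(C)C)nc32)cc1OCCCCCCC[N+]1(C)CCCC1`, gives 55.9%.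

From compound 1 to compound 2 the change is chloro in place of methyl on an aromatic carbon, and the result is a number 33.3 percentage points lower from compound 1 to compound 2 (beyond the scatter). Compound 3 has the same atoms as compound 1 joined differently; the difference between the two cores is not broken down here. Compound 4, `CN(C)c1ccc2c(=O)c(C(=O)Nc3cc(F)cc(F)c3)cn(-c3ccc(Cl)c(OCCCCCCC[N+]4(C)CCCC4)c3)c2n1`, has not been measured. It arises from compound 3 by chloro in place of methyl on an aromatic carbon. This is the same kind of change as that from compound 1 to compound 2, though around the place it sits para to a large group rather than meta to a large group. For compound 4 the expected step is a number 33.9 percentage points lower from compound 3 to compound 4 (beyond the scatter), resting on the earlier step of a number 33.3 percentage points lower from compound 1 to compound 2 (beyond the scatter). Compound 4 is thus estimated at 22% in this assay, between 2% and 45%.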

Compound 4, a percentage reported as inhibition, at one concentration (the size of the read-out at that concentration, not a potency): 76.1%
Beside the measured number, compound 4's estimate is 54.1 percentage points below it; the whole stated range lies below it.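

On the core of compound 3, chloro in place of methyl gives a number 20.2 percentage points higher from compound 3 to compound 4 (beyond the scatter) in this assay, the opposite direction from the core of compound 1. A step read on one of these cores therefore cannot simply be carried over to the other: the same change on two cores in this assay, a number 33.3 percentage points lower (beyond the scatter) from compound 1 to compound 2 and a number 20.2 percentage points higher (beyond the scatter) from compound 3 to compound 4, 53.5 percentage points apart, beyond the scatter of two such steps

These two pairs do not show why the cores respond differently, and each number is a read-out at a single concentration, not a potency. Open questions are how fluoro, bromo or methoxy at this same place would behave on each core, and whether a shorter or longer chain to the charged ring would alter the difference between the cores.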